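The compounds below may be only part of what the source reports. "The series", "measured", "known", "first", "only" and "open" are said of these compounds alone.

In a functional assay on NALM-6 cells (Homo sapiens) for cytotoxicity, read by MTT assay, with a stated time of 48 h (on this read-out higher numbers stand for weaker inhibition and lower numbers for stronger inhibition), compound 3 `O=C(Nc1cc(C(F)(F)F)ccc1Nc1ccc(Br)cc1)c1ccccc1` gives 6000 nM, the lowest of the two numbers available. Compound 2 `O=C(Nc1cc(C(F)(F)F)ccc1NC1CCCCC1)c1ccncc1` gives 59000 nM, a number far enough away to sit beyond the usual scatter. Compound 1 `O=C(Nc1cc(C(F)(F)F)ccc1N1CCCCC1)c1ccccc1` is reported as "not active" (no number reported). Compound 4 `O=C(Nc1cc(C(F)(F)F)ccc1NC1CCCCC1)c1ccccc1` has not yet been measured in this assay. The change from compound 3 is cyclohexyl in place of 4-bromophenyl on a nitrogen on an aromatic ring. Compound 4 shares its cyclohexylamino group with compound 2, whose number was the weaker one, and differs from compound 2 only in the amide end. The expected step is therefore a rise in the number, beyond the scatter, a 6.7-fold higher number from compound 3 to compound 4 (0.82 log units; beyond the scatter). Compound 4 is expected to reach about 40000 nM, estimated to lie between 10000 nM and 150000 nM.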

Compound 4, half-maximal inhibitory concentration: "not active" (no number reported)
For compound 4 the study gives words and no number; the estimate stays without a comparison.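

Going by these compounds alone, compound 3 has a number but compound 4 is reported only in words, so no step between them can be read, and no evidence on hand bears on this result. The compounds shown leave open how far, in this assay, cyclohexylamino in place of (4-bromophenyl)amino moves the number.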